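The source may hold more compounds than are shown below. What is called first, only, known or untested is meant among the compounds shown, and "the series" means these compounds.

Values in a functional assay for inhibition, with Homo sapiens as the target; on this read-out higher numbers stand for an effect only at larger amounts of compound and lower numbers for an effect already at smaller amounts:
Compound 1 `Nc1ccc(C2=NNC(=O)CC2)cc1`: 46.4 ug/mL
Compound 2 `CC(=O)Nc1cccc(C2=NNC(=O)CC2)c1`: > 46.4 ug/mL
Compound 3 `O=C1CCC(c2ccc(NC(=O)CCCl)cc2)=NN1`: 0.98 ug/mL

Compound 2 has the entry > 46.4 ug/mL, which is a limit of the assay, not a number. Of the two actual numbers, the lower belongs to compound 3 at 0.98 ug/mL, and the nearest is that of compound 1 at 46.4 ug/mL.

The next structure, compound 4 `CC(C)NCC(=O)Nc1ccc(C2=NNC(=O)CC2)cc1`, differs from compound 3 by isopropylamino in place of chloromethyl on a saturated chain carbon bound to a carbonyl carbon. Among the measured compounds shown here, one measured step bears on this: a 47-fold lower number from compound 1 to compound 3 (1.68 log units; beyond the scatter), a large step that came with the (2-chloroethyl)carbonyl group. For the measured compounds named here, compound 4 keeps the carbonyl but not the chlorine, and no measured compound carries an isopropylamino group. Part of the drop shown in a 47-fold lower number from compound 1 to compound 3 (1.68 log units; beyond the scatter) is therefore expected to be lost, giving a higher number in this assay. The expected change is an 8.2-fold higher number from compound 3 to compound 4 (0.91 log units; beyond the scatter). For compound 4 the estimated value is 8 ug/mL, with an expected range of 1 ug/mL to 46 ug/mL.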

Compound 4, half-maximal effective concentration: about 46.4 ug/mL
Beside the measured number, compound 4's estimate is 5.8-fold (0.76 log units) below it; measured number outside the range, above it.
By their numbers in this assay, from the lowest: compound 3; then compounds 1 and 4 (each within the scatter of the next).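

In this assay, putting isopropylamino in place of chloromethyl on a saturated chain carbon bound to a carbonyl carbon gives a 47-fold higher number from compound 3 to compound 4 (1.68 log units; beyond the scatter), so the low number of compound 3 does not survive this change at this position. The ((isopropylamino)methyl)carbonyl group in place of hydrogen on a nitrogen on an aromatic ring gives no change at the digits printed from compound 1 to compound 4 (within the scatter), which shows that a carbonyl on that nitrogen does not by itself bring the number down. Readings at this figure may lie close to the edge of what the assay resolves: the limit of > 46.4 ug/mL in this assay, at which 1 of the 4 values shown sits.

Going by these compounds, whether the low number of compound 3 depends on the chlorine itself or on the chain that carries it remains open. A bromine in place of the chlorine, a plain propanoyl chain or a smaller amine such as dimethylamino at the same place would bear on that question.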